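The source may hold more compounds than are shown below. What is called first, only, known or untested is meant among the compounds shown, and "the series" means these compounds.

Measured compounds:
compound 1 `COc1cc(SC)nc(NC(=S)NC(=O)c2c(-c3ccc(Cl)cc3Cl)noc2C)n1` — 69.2%
compound 2 `Cc1onc(-c2ccc(Cl)cc2Cl)c1C(=O)/N=c1/nc2nc(Cl)cc(C)n2s1` — 70.2%
compound 3 `COc1cc(SC)nc2n/c(=N/C(=O)c3c(-c4ccc(Cl)cc4Cl)noc3C)sn12` — 75.8%

Of the compounds shown here, three have been tested in a functional assay on the whole organism for inhibition, with Brassica napus as the target, with a stated time of 72 h, tested at 100 mg/L; on this read-out lower numbers stand for less inhibition of growth and higher numbers for more inhibition of growth at the one concentration tested. Compound 1 gives 69.2%, compound 2 gives 70.2% and compound 3 gives 75.8%. Compound 1 holds the lowest of the three numbers, but the gap to compound 2 is within the scatter, and so is the gap to compound 3; the three numbers cannot be told apart with confidence. Going by the values given here, no pair among them differs in a single place, so no measured step is available to guide an expectation.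

The piece now follows the step from compound 1 to compound 4 `Cc1cc(O)nc(NC(=S)NC(=O)c2c(-c3ccc(Cl)cc3Cl)noc2C)n1`, which has not yet been measured in this assay. The structures differ as follows: 4-hydroxy-6-methylpyrimidin-2-yl in place of 4-methoxy-6-(methylsulfanyl)pyrimidin-2-yl on an amide-type nitrogen. Compound 4 keeps the shared core of compound 1 and differs only in the group on the amide-type nitrogen next to the thiocarbonyl carbon. Among the compounds with values here, no measured step shows what such an exchange does in this assay, and the three measured numbers sit close together, so a step not beyond the scatter is expected from compound 1 to compound 4.

For compound 4 the expected result in this assay is 65%, with a range from 45% to 82%; this expectation means a step of a number 4.2 percentage points lower from compound 1 to compound 4 (within the scatter).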

Compound 4, percent growth inhibition at one concentration: 52.3%
Compound 4: the middle estimate sits 12.7 percentage points above what was measured, and the stated range covers the measured number.
By their numbers in this assay, from the lowest: compound 4; then compounds 1, 2 and 3 (each within the scatter of the next).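

The exchange of 4-methoxy-6-(methylsulfanyl)pyrimidin-2-yl for 4-hydroxy-6-methylpyrimidin-2-yl on the amide-type nitrogen is the only single-place change among these compounds, and in this assay it gives a number 16.9 percentage points lower from compound 1 to compound 4 (beyond the scatter) as the measured step. Going by these compounds alone, this shows that the read-out responds to the group on this nitrogen by more than the usual scatter, which the three earlier compounds could not show, as their numbers lay close together and no pair of them differed in one place. Nothing measured here accounts for this drop in growth inhibition.

The change replaces two substituents on the pyrimidine at once, so the compounds shown cannot separate the part played by the hydroxy group from that of the methyl group. Going by these compounds, it also remains open whether an amine in place of the hydroxy group, or a longer chain such as propyl in place of the methyl group, would keep the number near that of compound 1 or lower it further.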